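Sulfamate series: pyridin-2-yl to 4-bromophenyl swap on the amine arm

The compounds below may be only part of what the source reports. "The series", "measured", "known", "first", "only" and "open" are said of these compounds alone.

Measured in an assay on HEK293 cells for inhibition of Steryl-sulfatase (Homo sapiens), tested at 1 uM; a higher number here means a stronger effect of the compound at the concentration tested, a lower number a weaker effect:
compound 1 `CCN(Cc1ccccn1)c1ccc(C(=O)N2CCc3ccc(OS(N)(=O)=O)cc3C2)cc1` — 87.7%
compound 2 `CCN(Cc1ccccc1)Cc1ccc(S(=O)(=O)N2CCc3ccc(OS(N)(=O)=O)cc3C2)cc1` — 31%
compound 3 `NS(=O)(=O)Oc1ccc2c(c1)CN(C(=O)c1cccc(N3CCCCC3)c1)CC2` — 11.9%

Compound 1 gives the highest of the three inhibition values in this assay. The nearest number is that of compound 2, which lies lower by a gap beyond the usual scatter; the furthest is that of compound 3, lower again by a gap well beyond the scatter. Going by the values given here, no two measured compounds differ in only one place, so no single-change step can be read from the measured set, and what separates compound 1 from compound 2 and compound 3 can only be stated as their two values.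

Compound 4 `CCN(Cc1ccc(Br)cc1)c1ccc(C(=O)N2CCc3ccc(OS(N)(=O)=O)cc3C2)cc1` is the next compound, not yet measured. Among the compounds with values here, it keeps the shared core of compound 1 and changes only one group: 4-bromophenyl in place of pyridin-2-yl on a saturated chain carbon bound to a nitrogen on an aromatic ring.

With the core untouched and compound 1 giving 87.7% in this assay, the expected step of a number 7.7 percentage points lower from compound 1 to compound 4 (within the scatter) is a small decrease, likely within the scatter. Compound 4 is therefore estimated at 80% in this assay, with a range from 55% to 95%.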

Compound 4, a percentage reported as inhibition, at one concentration (the size of the read-out at that concentration, not a potency): 95.9%
Compound 4: the middle estimate sits 15.9 percentage points below what was measured; measured number above the stated range.
By their numbers in this assay, from the lowest: compound 3; then compound 2; then compounds 1 and 4 (each within the scatter of the next).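

In this assay, going by these compounds alone, 4-bromophenyl in place of pyridin-2-yl on a saturated chain carbon bound to a nitrogen on an aromatic ring gives a number 8.2 percentage points higher from compound 1 to compound 4 (within the scatter), the first single-place comparison in this set. The hydrogen-bond acceptor of pyridin-2-yl is thus not required at this position for a high read-out at the concentration tested, and a carbon-only ring carrying bromine reads alike. Nothing at hand bears on why the two groups read alike.

As far as these compounds go, it remains open whether this tolerance extends to a ring carrying a carboxylic acid or an amine, or to a longer chain in place of the ethyl group on the same nitrogen. A read-out at one concentration also leaves any difference in potency between compound 1 and compound 4 unresolved.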